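A Methoxy Group Added to the Phenyl of Compound 2

The source may report more compounds than this note shows. Statements on the series, on what has been measured and on what is new or still open speak of the compounds shown alone.

Of the compounds shown here, two have been measured for cytotoxicity. Compound 1 `COc1ccc(C2=NN(C3=NC(=O)/C(=C4\C(=O)Nc5ccccc54)S3)C(c3ccc(OC)cc3)C2)cc1` carries methoxy groups on both of its pendant aryl rings; in a functional assay on cells (Cancer cell lines, Homo sapiens) for cytotoxicity, read by sulforhodamine B assay, with a stated time of 48 h (a higher number here means a weaker inhibitor of growth, a lower number a stronger inhibitor of growth), compound 1 gives 99600 nM. Compound 2 `O=C1N=C(N2N=C(c3ccccc3)CC2c2ccc(Cl)cc2)S/C1=C1/C(=O)Nc2ccccc21` carries a chlorophenyl and an unsubstituted phenyl on the shared core; in this assay compound 2 gives 910 nM. Compound 2 therefore stands as the lower of the two numbers, and the gap to compound 1 lies well beyond the scatter of the method.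

Compound 3 `COc1ccc(C2=NN(C3=NC(=O)/C(=C4\C(=O)Nc5ccccc54)S3)C(c3ccc(Cl)cc3)C2)cc1` has not yet been measured. It differs from compound 2 in one place: methoxy in place of hydrogen on an aromatic carbon, so that the change is methoxy in place of hydrogen on an aromatic carbon. Compound 3 thus sits between compound 2 and compound 1, sharing the chlorophenyl of compound 2 and one of the two methoxyphenyl groups of compound 1.

Since compound 1, with both methoxy groups, gives 99600 nM, the step from compound 2 to compound 3 is expected to raise the number, with an estimated step of a 5.5-fold higher number from compound 2 to compound 3 (0.74 log units; beyond the scatter). For compound 3 in this assay, the expected value is 5000 nM, within a range of 1200 nM to 25000 nM.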

Compound 3, concentration for total growth inhibition: 100000 nM
The estimate for compound 3 lay 20-fold (1.30 log units) below the measured number; the measured number lies above the stated range.
By their numbers in this assay, from the lowest: compound 2; then compounds 1 and 3 (each within the scatter of the next).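

In this assay, the change from phenyl to 4-methoxyphenyl, with methoxy in place of hydrogen para to a large group, gives a 110-fold higher number from compound 2 to compound 3 (2.04 log units; beyond the scatter), so this single position is enough to separate compound 3 from compound 2 by a large step. The earlier pair could not show this, as compound 1 and compound 2 differ in more than one place and their gap could not be assigned to either aryl ring. With the 4-methoxyphenyl in place, chloro in place of methoxy on the other aromatic ring gives a 1.0-fold higher number from compound 1 to compound 3 (0.00 log units; within the scatter), so compound 1 and compound 3 cannot be told apart in this read-out, and nothing among the data shown gives a reason for the size of the methoxy step.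

The compounds shown leave open whether the loss follows methoxy in particular or would also appear with a hydroxyl group, a fluorine atom or an amine at the same place. They also leave open how a longer chain such as ethoxy would read there, and whether the chlorine of compound 2 matters while the other aryl ring remains an unsubstituted phenyl.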